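The compounds below may be only part of what the source reports. "The series", "measured", "known", "first", "only" and "open" are said of these compounds alone.

In a functional assay on HepG2 cells (Homo sapiens) for inhibition, read by MTT assay, with a stated time of 72 h (on this read-out higher numbers stand for weaker inhibition and lower numbers for stronger inhibition), compound 3 (`COc1ccc(-c2cc(C(=O)N3CCC4(CC3)CC(=O)c3nn(C(C)(C)C)cc3O4)c3ccccc3n2)cc1`) gives 2780 nM. Compound 1 (`Cc1ccc(-c2cc(C(=O)N3CCC4(CC3)CC(=O)c3nn(C(C)(C)C)cc3O4)c3ccccc3n2)cc1`) gives 1440 nM, and the two cannot be told apart, the step being a 1.9-fold higher number from compound 1 to compound 3 (0.29 log units; within the scatter). Compound 2 (`CC(C)(C)n1cc2c(n1)C(=O)CC1(CCN(C(=O)c3cc(-c4ccccc4Cl)nc4ccccc34)CC1)O2`) reads > 10000 nM, which is a limit of the assay and not a number. Compound 3 thus stands level with compound 1 and clear of compound 2, with an at least 3.5-fold lower number from compound 2 to compound 3 (0.55 log units; beyond the scatter).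

Compound 4 (`CC(C)(C)n1cc2c(n1)C(=O)CC1(CCN(C(=O)c3cc(-c4ccccn4)nc4ccccc34)CC1)O2`) carries pyridin-2-yl in place of 4-methoxyphenyl on an aromatic carbon, next to the ring nitrogen: pyridin-2-yl in place of 4-methoxyphenyl on an aromatic carbon. For the measured compounds named here, all the measured steps are exchanges at this same carbon. Moving between 4-methylphenyl and 4-methoxyphenyl stayed within the scatter, whereas 2-chlorophenyl gave an at least 6.9-fold higher number from compound 1 to compound 2 (0.84 log units; beyond the scatter), so the position can respond strongly. Going by the values given here, no measured compound has a hetero atom in this ring, so the direction of the change is poorly constrained. The one measured departure from the two 4-substituted phenyl groups, compound 2, went toward weaker inhibition, and a slight lean that way seems reasonable. The expected change in this assay is small, estimated as a 1.6-fold higher number from compound 3 to compound 4 (0.21 log units; within the scatter). For compound 4 the estimated value is 4500 nM, with an expected range of 1500 nM to 13000 nM.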

Compound 4, half-maximal inhibitory concentration: 1500 nM
The estimate for compound 4 lay 3.0-fold (0.48 log units) above the measured number, within the range that was stated.
By their numbers in this assay, from the lowest: compounds 1, 4 and 3 (each within the scatter of the next). At a limit, above all of these: compound 2.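

In this assay, compound 4, the only compound shown with a hetero atom in the ring at this aromatic carbon, cannot be told apart from the two compounds carrying 4-substituted phenyl groups: a 1.9-fold lower number from compound 3 to compound 4 (0.27 log units; within the scatter), and a 1.0-fold higher number from compound 1 to compound 4 (0.02 log units; within the scatter). Pyridin-2-yl carries neither the methyl of 4-methylphenyl nor the methoxy of 4-methoxyphenyl, so neither group is required to hold this level, and a ring nitrogen in the entering group is tolerated on this read-out. For the compounds shown here, compound 2 alone stands apart, with an at least 6.6-fold lower number from compound 2 to compound 4 (0.82 log units; beyond the scatter), so 2-chlorophenyl is no longer just a departure from the 4-substituted phenyl groups but the one group here that separates from the others, though this step rests on a limit and not a number: the limit of > 10000 nM in this assay, at which 1 of the 4 values shown sits.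

The compounds shown leave open whether the place of the ring nitrogen matters, as pyridin-3-yl or pyridin-4-yl would test, and whether the reading of compound 2 belongs to the chlorine itself or to where it sits, as 4-chlorophenyl would show. They also do not tell how this carbon responds to a group that is not an aromatic ring, such as morpholine or a carboxylic acid.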